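Isopropyl to 4-Bromophenyl on the Ring Nitrogen

The compounds below may be only part of what the source reports. "The series", "measured", "known", "first", "only" and "open" are said of these compounds alone.

Measured compounds:
compound 1 `COc1cc(-c2nccn2C(C)C)cc(OC)c1OC`: > 100000 nM
compound 2 `COc1ccc(-n2ccnc2-c2cc(OC)c(OC)c(OC)c2)cc1[N+](=O)[O-]`: 2500 nM
compound 3 `COc1cc(-c2nccn2-c2cccc([N+](=O)[O-])c2)cc(OC)c1OC`: 6700 nM

All three share one core and were tested in a functional assay on HeLa cells (Homo sapiens) for antiproliferative activity, read by MTT assay, with a stated time of 72 h; a higher number here means a weaker inhibitor, a lower number a stronger inhibitor. For compound 1 only a limit is known: it stands at the limit of > 100000 nM in this assay, at which 1 of the 3 values shown sits, so no number can be given for it. Compound 2, which bears an aromatic group on the ring nitrogen, gives 2500 nM. Compound 3, with a different aromatic group there, gives 6700 nM. For the measured compounds named here, the single measured step, a 2.7-fold higher number from compound 2 to compound 3 (0.43 log units; beyond the scatter), concerns hydrogen in place of methoxy on an aromatic carbon and does not touch the change described next.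

Compound 4 `COc1cc(-c2nccn2-c2ccc(Br)cc2)cc(OC)c1OC` differs from compound 1 by 4-bromophenyl in place of isopropyl on an aromatic nitrogen. Going by the values given here, no measured step covers this exact exchange. What the values of compounds 2 and 3 show is that, when an aromatic group sits on the ring nitrogen, this assay returns a number rather than a limit, whereas compound 1 with isopropyl there stays at the limit. On that basis a move into the measurable range is expected for compound 4, as the step of an at least 20-fold lower number from compound 1 to compound 4 (1.30 log units; beyond the scatter). The estimate for compound 4 is 5000 nM, with a range from 1500 nM to 25000 nM.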

Compound 4, half-maximal inhibitory concentration: 3300 nM
Estimate against measurement, compound 4: 1.5-fold (0.18 log units) above; low and high end bracket the measured number.
By their numbers in this assay, from the lowest: compounds 2 and 4 (each within the scatter of the next); then compound 3. At a limit, above all of these: compound 1.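

In this assay, for the compounds shown here, the exchange of isopropyl for 4-bromophenyl on the aromatic nitrogen gives an at least 30-fold lower number from compound 1 to compound 4 (1.48 log units; beyond the scatter), and this is the first comparison in which that position changes while the rest of the molecule stays the same. The earlier compounds shown here with an aromatic group on this nitrogen also differ from compound 1 in a second place, the nitro group on that ring, so they could only hint at what the group on the nitrogen does on its own; this single exchange ties the move from a limit into the measurable range to that position alone. Compound 1 is known only as a limit, and the full size of the step cannot be read from it.

The compounds shown leave open whether the ring itself or its bromine matters, a question that plain phenyl on the same nitrogen would address. They also leave open how other groups at this position would read in this assay, such as benzyl, which sets a carbon between the nitrogen and the ring, or a longer chain such as n-butyl.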